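The compounds below may be only part of what the source reports. "The series", "measured", "known", "first", "only" and "open" are said of these compounds alone.

In a functional assay on NCI-H522 cells (Homo sapiens) for cytotoxicity, with a stated time of 3 days (a lower number here means a stronger inhibitor, a higher number a weaker inhibitor), three compounds have been measured. Compound 1 `C#CCNC1CCC(c2csc(C#C)n2)=C1C` gives 2510 nM, compound 3 `C#Cc1nc2ccccc2o1` gives 1260 nM, and compound 2 `C#Cc1nc(C(=O)N2CCN(c3ccc(Cl)cc3)CC2)cs1` gives 28 nM. Compound 2 thus holds the lowest number of the three; compound 3 lies above it by a gap beyond the scatter, and compound 1 lies further above still, so compound 2 is the strongest inhibitor among the measured set.

Compound 4 `C#Cc1nc(C(=O)N2CCN(c3ccc(F)cc3)CC2)cs1` has not yet been measured. It differs from compound 2 in one place: fluoro in place of chloro on an aromatic carbon. Because compound 2 gives 28 nM, compound 4 starts from a low number, and the exchange of one halogen for another at the same place on the ring is a small change in size. For the measured compounds named here, no measured pair shows this exchange, so the direction rests on expectation alone. A modest rise in the number is expected, but one that may well fall within the scatter.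

The expected step from compound 2 to compound 4 is a 2.1-fold higher number from compound 2 to compound 4 (0.33 log units; beyond the scatter). For compound 4 the estimate in this assay is 60 nM, with a range from 20 nM to 200 nM.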

Compound 4, half-maximal inhibitory concentration: 64 nM
Compound 4: the middle estimate sits 1.1-fold (0.03 log units) below what was measured, within the range that was stated.
By their numbers in this assay, from the lowest: compound 2; then compound 4; then compounds 3 and 1 (each within the scatter of the next).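

In this assay, for the compounds shown here, the exchange of a 4-chlorophenyl for a 4-fluorophenyl provides the only one-place comparison in the set, and it gives a 2.3-fold higher number from compound 2 to compound 4 (0.36 log units; beyond the scatter). The halogen on this aromatic carbon, para to a large group, therefore affects the number, although this single pair shows only a modest step in one exchange. Nothing shown accounts for the direction or size of this step.

From the compounds shown here alone, it remains open how a hydrogen, a methyl group or a methoxy group at the same place would compare with chloro and fluoro. Going by these compounds, the contribution of the ethynyl group on the shared core also remains open, and a nitrile or a methyl group there would test it.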